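The source may hold more compounds than are shown below. What is called first, only, known or untested is meant among the compounds shown, and "the series" means these compounds.

In a functional assay on HepG2 cells (Homo sapiens) for antiproliferative activity, read by MTT assay, with a stated time of 24 h (a higher number here means a weaker inhibitor, a lower number a stronger inhibitor), three compounds sharing one core have been measured. Compound 1 `COc1cc(OC)c(-c2coc3cc(OCC=C(C)C)ccc3c2=O)cc1OC` gives 280 nM, compound 2 `C#CCOc1ccc2c(=O)c(-c3cc(OC)c(OC)cc3OC)coc2c1` gives 4950 nM, and compound 3 `COc1cc(OC)c(-c2coc3cc(OCc4ccc(Br)cc4)ccc3c2=O)cc1OC` gives 1050 nM, the middle of the three numbers. Compound 4 `COc1cc(OC)c(-c2coc3cc(OCc4ccc(C#N)cc4)ccc3c2=O)cc1OC` differs from compound 3 in one place: cyano in place of bromo on an aromatic carbon. Going by the values given here, no measured step makes this swap. The nearest evidence comes from replacing the whole group on the oxygen: a 3.8-fold higher number from compound 1 to compound 3 (0.57 log units; beyond the scatter), a 4.7-fold lower number from compound 2 to compound 3 (0.67 log units; beyond the scatter) and an 18-fold higher number from compound 1 to compound 2 (1.25 log units; beyond the scatter). Those steps show that the number can move with that group, but they give no direction for this smaller change. The expected step is a 1.1-fold lower number from compound 3 to compound 4 (0.02 log units; within the scatter), so none beyond the scatter is foreseen. Compound 4 is estimated at 1000 nM, with an expected range from 350 nM to 3000 nM.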

Compound 4, half-maximal inhibitory concentration: 4230 nM
Beside the measured number, compound 4's estimate is 4.2-fold (0.63 log units) below it, and the stated range ends below it.
By their numbers in this assay, from the lowest: compound 1; then compound 3; then compounds 4 and 2 (each within the scatter of the next).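

In this assay, a change of a single group on the benzyl ring moves the number: cyano in place of bromo on this aromatic carbon, para to a large group, gives a 4.0-fold higher number from compound 3 to compound 4 (0.61 log units; beyond the scatter). Going by these compounds alone, this carbon is therefore not indifferent to what it carries, which the earlier compounds could not show. Within the data shown here, with cyano here, the comparison with the ethynyl compound gives a 1.2-fold lower number from compound 2 to compound 4 (0.07 log units; within the scatter), while the one with the 2-methylprop-1-en-1-yl compound gives a 15-fold higher number from compound 1 to compound 4 (1.18 log units; beyond the scatter). No measurement here explains the step from bromo to cyano. On these data alone, whether an amine or a carboxylic acid on this carbon would give a number nearer that of compound 3 or that of compound 4 remains open.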